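The compounds below may be only part of what the source reports. "The series", "measured", "known", "first", "only" and "open" are said of these compounds alone.

Working notes on the series. Compound 1 `N[C@H]1CC[C@H](Nc2c(C(=O)NCc3ccccn3)nc(Br)c3cccnc23)CC1` carries the shared core with a trans-diaminocyclohexyl amine and a (pyridin-2-yl)methyl amide. In a functional assay on HCT-116 cells (Homo sapiens) for cytotoxicity, read by MTT assay, with a stated time of 72 h (a higher number here means a weaker inhibitor, a lower number a stronger inhibitor), compound 1 gives "not determined" (no result reported), so no number places it. Compound 2 `NCCNc1c(C(=O)NCc2ccc(F)cc2)nc(Br)c2cccnc12`, with a short aminoethyl amine and a 4-fluorobenzyl amide, is the one measured entry. In this assay compound 2 gives > 20000 nM, which is a limit of the assay and not a number. Compound 3 `O=C(NCc1ccc(F)cc1)c1nc(NCCO)c2cccnc2c1O`, a hydroxy analogue with a hydroxyethyl amine, gives "not determined" (no result reported) in this assay. Within the data shown here, the only evidence is the limit of > 20000 nM in this assay, at which 1 of the 3 values shown sits, a single limit and nothing to anchor compound 1.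

Compound 4 `N[C@H]1CC[C@H](Nc2c(C(=O)NCc3ccc(Cl)cc3Cl)nc(Br)c3cccnc23)CC1` differs from compound 1 by 2,4-dichlorophenyl in place of pyridin-2-yl on a saturated chain carbon bound to an amide-type nitrogen. Among the measured compounds shown here, with no measured step between any two compounds, no size or direction can be expected for this change beyond the usual scatter; compound 2 at its limit gives the only hint that this kind of benzyl amide on the core may be weak. Compound 4 is estimated at 6000 nM in this assay, expected between 600 nM and 20000 nM, with a real chance that only a limit is reported.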

Compound 4, half-maximal inhibitory concentration: 6000 nM
Compound 4: the middle estimate sits on the measured number at the digits printed; the measured number falls inside the stated range.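

No new step can be read from compound 4: in this assay compound 1 gives "not determined" (no result reported), and compound 2 differs from compound 4 in more than one place. The compounds shown leave open whether 2,4-dichlorophenyl in place of pyridin-2-yl shifts the read-out in this assay at all, and in which direction.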